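The compounds below may be only part of what the source reports. "The series", "measured", "known", "first", "only" and "open" are said of these compounds alone.

Three compounds with a shared core were tested for cytotoxicity in a functional assay on A549 cells (Homo sapiens) for cytotoxicity, read by MTT assay, with a stated time of 24 h, tested at 60 uM; a higher number here means a weaker effect of the compound at the concentration tested, a lower number a stronger effect. Compound 1, `CCCCCCCCCCOC(=O)CCC(=O)N1CCN(CCCOc2cc3c(Nc4ccc(F)c(Cl)c4)ncnc3cc2OC)CC1`, gives 3.9%. Compound 2, `CCCCCCCCCCCOC(=O)CCC(=O)N1CCN(CCCOc2cc3c(Nc4ccc(F)c(Cl)c4)ncnc3cc2OC)CC1`, gives 3.9%, and the step of no change at the digits printed from compound 1 to compound 2 (within the scatter) is the change (methyl in place of hydrogen on a saturated chain carbon, ten or more bonds along the chain from an oxygen next to a carbonyl group). Compound 3, `CCCCCCCCCCCCCCCCCCCOC(=O)CCC(=O)N1CCN(CCCOc2cc3c(Nc4ccc(F)c(Cl)c4)ncnc3cc2OC)CC1`, gives 89.3%; the difference from the core of compound 1 is nonyl in place of hydrogen on a saturated chain carbon, ten or more bonds along the chain from an oxygen next to a carbonyl group, and the resulting step is a number 85.4 percentage points higher from compound 1 to compound 3 (beyond the scatter), with a number 85.4 percentage points higher from compound 2 to compound 3 (beyond the scatter) telling the same story from compound 2.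

Compound 4, `CCCCCCCCCCCCCCCCCCCCOC(=O)CCC(=O)N1CCN(CCCOc2cc3c(Nc4ccc(F)c(Cl)c4)ncnc3cc2OC)CC1`, has not yet been measured in this assay. It differs from compound 3 by methyl in place of hydrogen on a saturated chain carbon, ten or more bonds along the chain from an oxygen next to a carbonyl group, the same change that was made from compound 1 to compound 2, where it gave no change at the digits printed from compound 1 to compound 2 (within the scatter). On that basis the step of a number 1.3 percentage points lower from compound 3 to compound 4 (within the scatter) is expected to be small, because compound 1 and compound 2 differ by the same change and show no change at the digits printed from compound 1 to compound 2 (within the scatter). Compound 4 is therefore estimated to give 88% in this assay, within a range from 65% to 100%.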

Compound 4, a percentage reported as activity, at one concentration (the size of the read-out at that concentration, not a potency): 86.9%
For compound 4 the middle estimate is 1.1 percentage points above the measured one, and the stated range covers the measured number.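

In this assay the methyl change gave a number 2.4 percentage points lower from compound 3 to compound 4 (within the scatter), and this carried over from the shorter chain to the longer one: the same change on two cores in this assay, no change at the digits printed (within the scatter) from compound 1 to compound 2 and a number 2.4 percentage points lower (within the scatter) from compound 3 to compound 4, 2.4 percentage points apart, within the scatter of two such steps

The larger extension carried over as well, with nonyl giving a number 83 percentage points higher from compound 2 to compound 4 (beyond the scatter) and decyl giving a number 83 percentage points higher from compound 1 to compound 4 (beyond the scatter), and the nonyl step agrees with the one seen earlier: the same change on two cores in this assay, a number 85.4 percentage points higher (beyond the scatter) from compound 1 to compound 3 and a number 83 percentage points higher (beyond the scatter) from compound 2 to compound 4, 2.4 percentage points apart, within the scatter of two such steps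

These comparisons show agreement for only two pairs of cores at the two ends of the chain lengths shown; they do not show that the methyl change stays small at every chain length, nor do they explain the large steps.

The compounds shown leave open how the read-out behaves for chains of intermediate length, and so where between compound 2 and compound 3 the large rise sets in, and whether it is gradual or abrupt. They also leave open whether the same steps would hold for a branched chain or for a chain ending in an amine or a carboxylic acid.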